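The source may report more compounds than this note shows. Statements on the series, on what has been measured and on what is new or still open speak of the compounds shown alone.

Compound 1 `CC(=O)Oc1ccc2c(c1)C(C)=CC(C)(C)N2Cc1ccc(C)cc1` sets the weaker end of the pair so far: in an ADME assay on L6 cells (Rattus norvegicus) for cytotoxicity, read by resazurin assay, with a stated time of 70 h (a lower number here means a stronger inhibitor, a higher number a weaker inhibitor), compound 1 gives 21000 nM, the highest of the two numbers, while compound 2 `CC(=O)Oc1ccc2c(c1)C(C)=CC(C)(C)N2Cc1ccc(C(C)(C)C)cc1` gives 9000 nM. Going by the values given here, the only step measured, a 2.3-fold lower number from compound 1 to compound 2 (0.37 log units; beyond the scatter), came from a tert-butyl in place of a methyl on the aromatic carbon. Compound 3 `CC(=O)Oc1ccc2c(c1)C(C)=CC(C)(C)N2C` differs from compound 1 by hydrogen in place of 4-methylphenyl on a saturated chain carbon bound to a nitrogen on an aromatic ring in a ring. Among the compounds with values here, no measured step removes the aryl group, and the one step available points toward a larger group lowering the number, so taking the group away is expected to run the other way, by a modest step of a 1.7-fold higher number from compound 1 to compound 3 (0.22 log units; within the scatter). Compound 3 is therefore expected to give about 35000 nM in this assay, between 15000 nM and 80000 nM.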

Compound 3, half-maximal inhibitory concentration: 41000 nM
The estimate for compound 3 lay 1.2-fold (0.07 log units) below the measured number; the measured number falls inside the stated range.
By their numbers in this assay, from the lowest: compound 2; then compounds 1 and 3 (each within the scatter of the next).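

In this assay the change from 4-methylbenzyl to methyl gives a 2.0-fold higher number from compound 1 to compound 3 (0.29 log units; within the scatter) and so does not separate the two compounds. Going by these compounds alone, at this position, the full loss of the 4-methylphenyl group therefore registers less clearly than the tert-butyl for methyl swap on the aromatic carbon, which was the only step beyond the scatter so far. Nothing at hand explains this result.

Still open, as far as these compounds go, is how a longer chain such as n-butyl in place of the methyl of compound 3 would read in this assay. From the compounds shown here alone, the effect of an amine or a carboxylic acid on the aromatic ring of compound 1 is equally open.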